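Second alkyl chain on the amino nitrogen of the core

The source may report more compounds than this note shows. Statements on the series, on what has been measured and on what is new or still open speak of the compounds shown alone.

Compound 1 `CCCCNc1cc(C)nc2c(-c3ccc(Cl)cc3Cl)nn(C)c12` carries a butylamino group on the shared core; in an assay on HEK293 cells for displacement of a labelled ligand from corticotropin-releasing factor receptor 1 (Homo sapiens) (on this read-out lower numbers stand for stronger inhibition and higher numbers for weaker inhibition), compound 1 gives 170 nM. Compound 2 `CCCCN(CCCC)c1cc(C)nc2c(-c3ccc(Cl)cc3Cl)nn(C)c12` carries dibutylamino, and in this assay compound 2 gives 0.62 nM. Compound 3 `CCCCCN(CCC)c1cc(C)nc2c(-c3ccc(Cl)cc3Cl)nn(C)c12` carries pentyl(propyl)amino; in this assay compound 3 gives 1.2 nM. Of the three numbers compound 3 is the second highest, closest to compound 2 and farthest from compound 1. The two large steps in the set, a 270-fold lower number from compound 1 to compound 2 (2.44 log units; beyond the scatter) and a 140-fold lower number from compound 1 to compound 3 (2.15 log units; beyond the scatter), both concern the move from one alkyl chain to two. The step between the two dialkyl members reads a 1.9-fold higher number from compound 2 to compound 3 (0.29 log units; within the scatter), a redistribution of the chains with no change beyond the scatter.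

Compound 4 `CCCCCN(CCCC)c1cc(C)nc2c(-c3ccc(Cl)cc3Cl)nn(C)c12` is the next dialkyl member: methyl in place of hydrogen on a saturated chain carbon, three bonds along the chain from a nitrogen on an aromatic ring. The step that bears on it most directly is a 1.9-fold higher number from compound 2 to compound 3 (0.29 log units; within the scatter), since compound 4 keeps two chains and only lengthens one of them. The steps from compound 1 indicate that the second chain carries the gain, not its exact length. No step beyond the scatter is therefore expected, and the estimated step is a 1.3-fold lower number from compound 3 to compound 4 (0.12 log units; within the scatter). Compound 4 is estimated at 0.9 nM, with a range from 0.3 nM to 2.7 nM.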

Compound 4, inhibition constant: 0.9 nM
The estimate for compound 4 equals the measured number at the digits printed, within the range that was stated.
By their numbers in this assay, from the lowest: compounds 2, 4 and 3 (each within the scatter of the next); then compound 1.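

In this assay, methyl in place of hydrogen on a saturated chain carbon, three bonds along the chain from a nitrogen on an aromatic ring, reads a 1.3-fold lower number from compound 3 to compound 4 (0.12 log units; within the scatter), and the same exchange four bonds along the chain reads a 1.5-fold higher number from compound 2 to compound 4 (0.16 log units; within the scatter), so both readings of compound 4 stay within the scatter. With the pair of dialkyl members now a set of three, the chain lengths can be altered on either side of the nitrogen, with propyl, butyl and pentyl all represented, and no listed step among compound 2, compound 3 and compound 4 leaves the scatter. The large gain also holds with pentyl as the added chain, at a 190-fold lower number from compound 1 to compound 4 (2.28 log units; beyond the scatter), and no measurement on hand accounts for any of these steps.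

As far as these compounds go, whether this flat stretch continues to a hexyl or longer chain, or holds for a branched chain such as isobutyl, stays open. Also open, from the compounds shown here alone, is whether a cyclopropylmethyl group or a methoxyethyl chain in place of one alkyl chain fits the same reading.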